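This account rests on a few compounds, and the source may have more. Where it says the series, first, only, none or still open, it means among the compounds named here.

Measured compounds in an assay on brain for binding affinity to Neuronal acetylcholine receptor; alpha4/beta2 (Rattus norvegicus), read by radioligand binding; on this read-out lower numbers stand for stronger inhibition and higher numbers for weaker inhibition:
- compound 1 `Cc1ccc(OC[C@@H]2CCN2)cn1` gives 0.057 nM
- compound 2 `Clc1ncccc1OC[C@@H]1CCN1` gives 2.3 nM
- compound 3 `Cc1ncccc1OC[C@@H]1CCN1` gives 1.36 nM

Among these three, compound 2 shows the highest number in this assay, which is the weakest binding of the set. Its nearest neighbour is compound 3, and the change a 1.7-fold lower number from compound 2 to compound 3 (0.23 log units; within the scatter) is within the scatter, so the two cannot be ordered. Compound 1 stands far away, a much lower number than compound 2, a gap well beyond the scatter.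

Compound 4 `Clc1ncccc1OC[C@H]1CCN1` has not yet been measured. It differs from compound 2 as follows: the two compounds have the same atoms and bonds and differ only in configuration as drawn: 1 of 1 stereo elements differ; a stereocentre at a saturated ring carbon is drawn S in compound 2 and R in compound 4. The two are mirror images of one another at the single ring stereocentre.

Going by the values given here, none of the measured steps bears on this change: the only step, from compound 2 to compound 3, swaps one group on the aromatic ring for another and keeps the stereocentre fixed, so nothing here shows what inverting that centre does. For a compound whose binding depends on a single stereocentre, the mirror image is often a weaker binder, so an upward shift in this assay is expected, but with low confidence. The expected step of an 8.7-fold higher number from compound 2 to compound 4 (0.94 log units; beyond the scatter) is therefore tentative. Compound 4 is estimated at 20 nM, with a range from 3 nM to 200 nM.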

Compound 4, inhibition constant: 85 nM
For compound 4 the middle estimate is 4.3-fold (0.63 log units) below the measured one, within the range that was stated.
By their numbers in this assay, from the lowest: compound 1; then compounds 3 and 2 (each within the scatter of the next); then compound 4.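

In this assay, inverting the single stereocentre at the saturated ring carbon gives a 37-fold higher number from compound 2 to compound 4 (1.57 log units; beyond the scatter), a large step well beyond the scatter. Going by these compounds alone, by contrast, the earlier swap of chloro for methyl on the aromatic carbon gave only a 1.7-fold lower number from compound 2 to compound 3 (0.23 log units; within the scatter), and the earlier compounds all kept this stereocentre as drawn, so they could not show that its configuration matters. In this pair, the S form gives the lower number and so the stronger binding, and the whole step can be assigned to the stereocentre alone because no atom or bond changes: the fact that compounds 2 and 4 differ only in the configuration as drawn.

The pair shows how much the configuration matters with chloro on the aromatic ring, but it leaves open whether inverting the centre would produce a step of similar size in compound 1 or compound 3, whose mirror images are not among the compounds shown. It also leaves open how a methoxy or a bromo group in place of chloro would behave in each configuration, and whether the S form would still give the lower number with those groups.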